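From compound 3 to compound 4: a furan-3-yl exchange

The compounds below may be only part of what the source reports. "The series", "measured", "known", "first", "only" and "open" are said of these compounds alone.

Measured in an ADME assay on BJ cells (Homo sapiens), read by MTT assay, with a stated time of 72 h; on this read-out lower numbers stand for stronger inhibition and higher numbers for weaker inhibition:
compound 1 `CNc1ncnc2c1c(-c1ccoc1)cn2[C@@H]1O[C@H](CO)[C@@H](O)[C@H]1O` gives 96300 nM here
compound 2 `CNc1ncnc2c1c(-c1cc3ccccc3o1)cn2[C@@H]1O[C@H](CO)[C@@H](O)[C@H]1O` gives 75600 nM here
compound 3 `CN(C)c1ncnc2c1c(-c1ccoc1)cn2[C@@H]1O[C@H](CO)[C@@H](O)[C@H]1O` gives 99200 nM here

The three values sit close together. Compound 3 (99200 nM) lies within the scatter of both compound 1 (96300 nM) and compound 2 (75600 nM), so the set shows no separation by potency.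

Compound 4 `CN(C)c1ncnc2c1c(-c1cc3ccccc3o1)cn2[C@@H]1O[C@H](CO)[C@@H](O)[C@H]1O` has not yet been measured. It differs from compound 3 by one exchange on the shared core, with 1-benzofuran-2-yl in place of furan-3-yl on an aromatic carbon. The same exchange has been measured once, as a 1.3-fold lower number from compound 1 to compound 2 (0.11 log units; within the scatter) in the series, and that step stays within the scatter. For the measured compounds named here, the only other measured step, the methyl in place of hydrogen on a nitrogen, is a 1.0-fold higher number from compound 1 to compound 3 (0.01 log units; within the scatter) and also stays within the scatter. Two small steps are thin evidence, but neither suggests a real shift. No step beyond the scatter is expected in this assay, with a slight lean towards a lower number following compound 2 (75600 nM). The estimate for the exchange is a small expected change (a 1.2-fold lower number from compound 3 to compound 4 (0.09 log units; within the scatter)). Compound 4 is expected at 80000 nM with an estimated range from 48000 nM to 125000 nM in this read-out.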

Compound 4, half-maximal inhibitory concentration: > 100000 nM
Compound 4: a limit, no number; the forecaster's own chance of this, stated with the estimate: 20%; middle value at least 1.2-fold (0.09 log units) away from the limit.
By their numbers in this assay, from the lowest: compounds 2, 1 and 3 (each within the scatter of the next). At a limit, above all of these: compound 4.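

In this assay compound 4 gives > 100000 nM, which is a limit of the assay and not a number, so the step from compound 3 to compound 4 cannot be read in size, beyond being a number no lower. For the compounds shown here, with 1-benzofuran-2-yl on this aromatic carbon, methyl in place of hydrogen on the nitrogen gives an at least 1.3-fold higher number from compound 2 to compound 4 (0.12 log units; that floor lies within the scatter), so this position shows no step established beyond the scatter, while the upper size stays open: the same change on two cores in this assay, a 1.0-fold higher number (0.01 log units; within the scatter) from compound 1 to compound 3 and an at least 1.3-fold higher number (0.12 log units; that floor lies within the scatter) from compound 2 to compound 4; the limit leaves it open whether they differ. The exchange of furan-3-yl for 1-benzofuran-2-yl has now been seen on a second core, and there it gives a number no lower from compound 3 to compound 4 (the limit leaves the size open), but the comparison between the two cores cannot be settled: the same change on two cores in this assay, a 1.3-fold lower number (0.11 log units; within the scatter) from compound 1 to compound 2 and a number no lower (the limit leaves the size open) from compound 3 to compound 4; the limit leaves it open whether they differ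

Still open is how far compound 4 really lies from compound 3, and the ceiling of the read-out limits any further comparison among these weak values: the limit of > 100000 nM in this assay, at which 1 of the 4 values shown sits. Also open, as far as these compounds go, is how this assay would respond to an amine or a carboxylic acid on this aromatic carbon in place of furan-3-yl or 1-benzofuran-2-yl.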